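A few compounds are considered here, and "the series" means these few. Any claim that something is new, unique, unknown or untested is made for them only; others in the source may bear on it.

In a functional assay on isolated protein for agonist activity at Glucose-dependent insulinotropic receptor (Rattus norvegicus), read by HTRF and cAMP accumulation (on this read-out lower numbers stand for an effect already at smaller amounts and higher numbers for an effect only at larger amounts of compound), compound 3 `CS(=O)(=O)c1cnc(O[C@H]2CC[C@H](OC3CCN(CC4(C(F)(F)F)CCCC4)CC3)CC2)cn1` gives 101 nM, the lowest number of the three shown, though it sits within the scatter of compound 1 `CC1(OC(=O)N2CCC(O[C@H]3CC[C@H](Oc4cnc(S(C)(=O)=O)cn4)CC3)CC2)CC1`, which gives 138 nM; compound 2 `C[C@@H](CF)OC(=O)N1CCC(O[C@H]2CC[C@H](Oc3cnc(S(C)(=O)=O)cn3)CC2)CC1` gives 356 nM. Compound 4 `CC(F)Cc1nc(CN2CCC(O[C@H]3CC[C@H](Oc4cnc(S(C)(=O)=O)cn4)CC3)CC2)no1` differs from compound 3 by a group of 9 heavy atoms (5 carbon, 2 nitrogen, 1 oxygen, 1 fluorine; one five-membered aromatic ring with 3 hetero atoms) in place of a group of 9 heavy atoms (6 carbon, 3 fluorine; one five-membered non-aromatic ring of carbon only), on a saturated chain carbon bound to an amine nitrogen in a ring. The measured steps that bear on the group on the amine nitrogen in a ring were a 1.4-fold lower number from compound 1 to compound 3 (0.14 log units; within the scatter) and a 3.5-fold lower number from compound 2 to compound 3 (0.55 log units; beyond the scatter); both swap that group, yet neither brings in an aromatic ring with hetero atoms there, so they frame the outcome without fixing it. Compound 4 is therefore expected to land near compound 3 or modestly higher, with a 2.2-fold higher number from compound 3 to compound 4 (0.34 log units; beyond the scatter). The estimate for compound 4 is 220 nM, within a range from 70 nM to 700 nM.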

Compound 4, half-maximal effective concentration: 267 nM
Compound 4: the middle estimate sits 1.2-fold (0.08 log units) below what was measured, within the range that was stated.
By their numbers in this assay, from the lowest: compounds 3, 1, 4 and 2 (each within the scatter of the next, the first and the last beyond it).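

In this assay, the first aromatic ring with hetero atoms at this place, 5-(2-fluoropropyl)-1,2,4-oxadiazol-3-yl, keeps a measurable effect but gives a 2.6-fold higher number from compound 3 to compound 4 (0.42 log units; beyond the scatter). Set against the two groups on the amine nitrogen in a ring that hold a carbonyl, the swap gives a 1.3-fold lower number from compound 2 to compound 4 (0.12 log units; within the scatter) and a 1.9-fold higher number from compound 1 to compound 4 (0.29 log units; within the scatter), so neither step separates those pairs. Nothing available explains the step away from the fluorinated cyclopentyl group. As far as these compounds go, whether the fluorine of the 2-fluoropropyl chain contributes remains open, as does the outcome with a plain propyl chain or an amine on that ring.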